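The compounds below may be only part of what the source reports. "The series", "measured", "known", "first", "only" and "open" are said of these compounds alone.

Compound 1 `Cc1ccc(-c2nn(-c3ccccc3)cc2C(=O)NOCc2ccccc2)cc1` and compound 2 `Cc1ccc(-c2nn(-c3ccccc3)cc2C(=O)NOCc2ccc(Cl)cc2Cl)cc1` share one core. In an ADME assay on HEK-293T cells (Homo sapiens) for antiproliferative activity, read by MTT assay, with a stated time of 48 h, in the presence of a further agent that is not named here (on this read-out higher numbers stand for lower toxicity in this test and lower numbers for higher toxicity in this test), compound 1 gives 40800 nM, and in this assay compound 2 gives 39600 nM. The two numbers lie within the scatter of each other, as the step of a 1.0-fold lower number from compound 1 to compound 2 (0.01 log units; within the scatter) shows. Compound 3 `O=C(NOCc1ccc(Cl)cc1Cl)c1cn(-c2ccccc2)nc1-c1ccc(F)cc1` differs from compound 2 by fluoro in place of methyl on an aromatic carbon. Within the data shown here, the only measured step touched a different part of the molecule and stayed within the scatter, so nothing here points to a shift. The step of a 1.0-fold lower number from compound 2 to compound 3 (0.01 log units; within the scatter) is therefore expected to stay within the scatter. Compound 3 is estimated at 39000 nM, with a likely range from 20000 nM to 80000 nM.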

Compound 3, half-maximal cytotoxic concentration: 45000 nM
Estimate against measurement, compound 3: 1.2-fold (0.06 log units) below; the range from low to high includes it.
By their numbers in this assay, from the lowest: compounds 2, 1 and 3 (each within the scatter of the next).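

In this assay, the change from 4-methylphenyl to 4-fluorophenyl gives a 1.1-fold higher number from compound 2 to compound 3 (0.06 log units; within the scatter). This adds a second site to the one changed earlier, here an aromatic carbon para to a large group, and the number again stays within the scatter. Nothing measured here offers an explanation for this result. Going by these compounds, whether an amine or a carboxylic acid on this carbon would also stay within the scatter remains open. So does whether any change at this carbon could move the number beyond the scatter.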